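Swapping a Methyl for Trifluoromethyl on the Shared Core

The source may report more compounds than this note shows. Statements on the series, on what has been measured and on what is new or still open speak of the compounds shown alone.

Of the compounds shown here, two sharing one core have been measured so far. Compound 1 `C=CC(=O)N1C(=O)CC(c2ccc(C)cc2)Sc2ccccc21` and compound 2 `C=CC(=O)N1C(=O)CC(c2ccc(C(=O)OC)cc2)Sc2ccccc21` differ only in one group on the outer aromatic ring. In a functional assay on MOLT-4 cells (Homo sapiens) for cytotoxicity, read by CCK-8 assay, with a stated time of 24 h (on this read-out higher numbers stand for weaker inhibition and lower numbers for stronger inhibition), compound 1 gives 87600 nM, the higher of the two numbers shown, though its gap to compound 2 lies within the scatter; in this assay compound 2 gives 79600 nM. The step between them, a 1.1-fold lower number from compound 1 to compound 2 (0.04 log units; within the scatter), shows that methoxycarbonyl in place of methyl left the read-out essentially unchanged.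

Compound 3 `C=CC(=O)N1C(=O)CC(c2ccc(C(F)(F)F)cc2)Sc2ccccc21` has not yet been measured. It differs from compound 1 by trifluoromethyl in place of methyl on an aromatic carbon. For the measured compounds named here, the only measured step that bears on this change is the one from compound 1 to compound 2, which stayed within the scatter, so no step beyond the scatter is expected in this assay. Compound 3 is therefore expected to give about 80000 nM, within a range from 30000 nM to 200000 nM. This corresponds to an expected 1.1-fold lower number from compound 1 to compound 3 (0.04 log units; within the scatter).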

Compound 3, half-maximal inhibitory concentration: 76300 nM
Compound 3: the middle estimate sits 1.0-fold (0.02 log units) above what was measured, and the stated range covers the measured number.
By their numbers in this assay, from the lowest: compounds 3, 2 and 1 (each within the scatter of the next).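

Trifluoromethyl is a second replacement for methyl on this aromatic carbon, and in this assay it gives a 1.1-fold lower number from compound 1 to compound 3 (0.06 log units; within the scatter). Set against methoxycarbonyl, the same group gives a 1.0-fold lower number from compound 2 to compound 3 (0.02 log units; within the scatter), so methyl, methoxycarbonyl and trifluoromethyl cannot be told apart at this position on this read-out, where the earlier pair alone offered only two groups to compare. No measurement at hand offers an explanation for this flat result.

The compounds shown leave open whether a different kind of group at this position, such as an amine, a carboxylic acid or a longer chain, would move the number beyond the scatter. They also leave open whether a change elsewhere on the shared core would matter more than any change made here.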